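The source may report more compounds than this note shows. Statements on the series, on what has been measured and on what is new or still open speak of the compounds shown alone.

Measured in a functional assay on MCF7 cells (Homo sapiens) for antiproliferative activity, read by MTT assay, with a stated time of 72 h; on this read-out lower numbers stand for stronger inhibition and higher numbers for weaker inhibition:

compound 1 `COc1ncc(-c2ccc3c(c2)N(c2ccc(C)cc2)C(=O)CO3)cc1NS(=O)(=O)c1ccc(F)cc1`: 15400 nM
compound 2 `COc1ncc(-c2ccc3c(c2)NC(=O)CO3)cc1NS(=O)(=O)c1ccc(F)cc1`: 32300 nM
compound 3 `COc1cccc(N2C(=O)COc3ccc(-c4cnc(OC)c(NS(=O)(=O)c5ccc(F)cc5)c4)cc32)c1`: > 40000 nM

The entry for compound 3 is a limit and not a number. Going by these compounds, compound 3 stands at the limit of > 40000 nM in this assay, at which 1 of the 3 values shown sits, so its true position in this assay remains open.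

Compound 4 `COc1ncc(-c2ccc3c(c2)N(c2ccc(F)cc2)C(=O)CO3)cc1NS(=O)(=O)c1ccc(F)cc1` has 4-fluorophenyl in place of 3-methoxyphenyl on an amide-type nitrogen in a ring, and the difference is 4-fluorophenyl in place of 3-methoxyphenyl on an amide-type nitrogen in a ring.

For the measured compounds named here, three measured steps bear on this change, all at the same nitrogen. The closest is an at least 2.5-fold higher number from compound 1 to compound 3 (0.41 log units; beyond the scatter), which swaps a 4-methylphenyl group for the 3-methoxyphenyl group that compound 4 gives up. Removing the aryl group altogether also counts, in a 2.1-fold higher number from compound 1 to compound 2 (0.32 log units; beyond the scatter). The third step, an at least 1.2-fold higher number from compound 2 to compound 3 (0.09 log units; that floor lies within the scatter), separates the hydrogen from the 3-methoxyphenyl group only by a floor within the scatter.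

If 4-fluorophenyl behaves like the 4-methylphenyl of compound 1, which gives 15400 nM, a modest step towards a lower number is expected in this assay. The expected step is an at least 2.0-fold lower number from compound 3 to compound 4 (0.30 log units; that floor lies within the scatter). The estimated value for compound 4 is 20000 nM, with an expected range from 9000 nM to 40000 nM.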

Compound 4, half-maximal inhibitory concentration: > 40000 nM
Compound 4 gave a limit, no number (the forecaster's own chance of this, stated with the estimate: 25%); at least 2.0-fold (0.30 log units) between middle value and limit.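

In this assay, for the compounds shown here, the earlier compounds left open whether the activity of compound 1 would carry over to another para-free reading of the aryl group, and the entry for compound 4, a limit and not a number, shows that it does not: a small swap of fluoro in place of methyl on an aromatic carbon already gives an at least 2.5-fold higher number from compound 1 to compound 4 (0.41 log units; beyond the scatter). Compound 1 is thus the only compound shown with an aryl group on the amide-type nitrogen that gives a number, so an aryl group there does not by itself hold the value, and the outcome depends on which aryl group enters. Against hydrogen on that nitrogen, the change gives an at least 1.2-fold higher number from compound 2 to compound 4 (0.09 log units; that floor lies within the scatter), so no order can be claimed for that pair, and the step between the 3-methoxyphenyl and 4-fluorophenyl groups cannot be read, since both entries are limits: the limit of > 40000 nM in this assay, at which 2 of the 4 values shown sit.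

Going by these compounds, how far compound 3 and compound 4 each lie past their limits stays open, and with it any ranking of the two groups. Also open, on these data alone, is whether a 4-chlorophenyl, a 4-aminophenyl or a benzyl group on that nitrogen would give a number like compound 1 or a limit like compound 4.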